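Hydroxy in place of dimethylamino, with only limits so far

The source may hold more compounds than are shown below. What is called first, only, known or untested is meant among the compounds shown, and "the series" means these compounds.

In a toxicity assay on MDCK cells (Canis lupus familiaris) for cytotoxicity, read by CCK-8 assay, with a stated time of 48 h (on this read-out lower numbers stand for higher toxicity in this test and higher numbers for lower toxicity in this test), three compounds sharing one core have been read so far. Compound 1 (`CCc1ccc(C(=O)NNc2c(Br)cccc2Br)cc1`) gives > 100000 nM as a limit of the assay. Compound 2 (`O=C(NNc1c(Br)cccc1Br)c1ccc(F)cc1`) gives > 100000 nM as a limit of the assay. Compound 3 (`CN(C)c1ccc(C(=O)NNc2c(Br)cccc2Br)cc1`) gives > 100000 nM as a limit of the assay. Compound 3 therefore has no number to its name, and the series as a whole stands at the limit of > 100000 nM in this assay, at which 3 of the 3 values shown sit, with no exception so far.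

Compound 4 (`O=C(NNc1c(Br)cccc1Br)c1ccc(O)cc1`) differs from compound 3 in one group, hydroxy in place of dimethylamino on an aromatic carbon, para to a large group: hydroxy in place of dimethylamino on an aromatic carbon is the counted change.

Three measured steps at this same place bear on it: a step that the two limits leave unreadable from compound 1 to compound 2 and a step that the two limits leave unreadable from compound 1 to compound 3 and a step that the two limits leave unreadable from compound 2 to compound 3 all the same in having no readable size. Ethyl, fluoro and dimethylamino thus give no number among them. With compound 3 at > 100000 nM as a limit and these steps unreadable, no step beyond the scatter is expected in this assay and no direction can be favoured. The expected step is a number no higher from compound 3 to compound 4 (the limit leaves the size open) by this estimate. For compound 4 the estimated value is 100000 nM with an expected range from 40000 nM to 200000 nM and another limit is the likeliest report.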

Compound 4, half-maximal cytotoxic concentration: > 100000 nM
Compound 4: a limit, no number (the forecaster's own chance of this, stated with the estimate: 80%); the middle value lies on the limit itself.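

Compound 4 gives only a limit in this assay, as compounds 1, 2 and 3 do, so no step among these four compounds can be read: the limit of > 100000 nM in this assay, at which 4 of the 4 values shown sit.

The compounds shown leave open whether ethyl, fluoro, dimethylamino and hydroxy differ at all in this assay, and at what concentration any of these compounds would give a numerical value.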